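Four quinazoline ureas tested for cytotoxicity on breast cancer cells

The compounds below may be only part of what the source reports. "The series", "measured", "known", "first", "only" and "open" are said of these compounds alone.

Of the compounds shown here, three from one series have been measured in a functional assay on MCF7 cells (Homo sapiens) for cytotoxicity, read by MTT assay, with a stated time of 72 h; on this read-out higher numbers stand for weaker inhibition and lower numbers for stronger inhibition. Compound 1 `O=C(N/N=C/c1ccc(O)cc1O)Nc1cc2c(Nc3ccc(F)c(Cl)c3)ncnc2cc1O[C@H]1CCOC1` gives 5350 nM in this assay. Compound 2 `CCN(CC)c1ccc(/C=N/NC(=O)Nc2cc3c(Nc4ccc(F)c(Cl)c4)ncnc3cc2O[C@H]2CCOC2)c(O)c1` gives 15600 nM in this assay. Compound 3 `COc1cc2ncnc(Nc3ccc(F)c(Cl)c3)c2cc1NC(=O)N/N=C/c1ccc(O)cc1O` gives 36200 nM in this assay, the highest of the three numbers.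

Two single changes connect these measured compounds. From compound 1 to compound 2 the change is diethylamino in place of hydroxy on an aromatic carbon and it made a 2.9-fold higher number from compound 1 to compound 2 (0.46 log units; beyond the scatter). From compound 1 to compound 3 the change is methyl in place of oxolan-3-yl on an oxygen on an aromatic ring and it made a 6.8-fold higher number from compound 1 to compound 3 (0.83 log units; beyond the scatter).

Compound 4 `CCN(CC)c1ccc(/C=N/NC(=O)Nc2cc3c(Nc4ccc(F)c(Cl)c4)ncnc3cc2OC)c(O)c1` has not yet been measured. It carries the core of compound 3 and differs from it by diethylamino in place of hydroxy on an aromatic carbon. Going by the values given here, this is the same change as the one from compound 1 to compound 2, made on the other core; the surroundings of the place are described in the same words in both cases. The two cores differ by methyl in place of oxolan-3-yl on an oxygen on an aromatic ring.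

Because the same change gave a 2.9-fold higher number from compound 1 to compound 2 (0.46 log units; beyond the scatter), a step of similar size is expected from compound 3 to compound 4 in this assay, namely a 2.6-fold higher number from compound 3 to compound 4 (0.42 log units; beyond the scatter), though this rests on a single prior instance on a different core. Compound 4 is therefore estimated to give 95000 nM in this assay, with a likely range from 40000 nM to 220000 nM.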

Compound 4, half-maximal inhibitory concentration: 27300 nM
Compound 4: the middle estimate sits 3.5-fold (0.54 log units) above what was measured; the whole stated range lies above it.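

In this assay, diethylamino in place of hydroxy on an aromatic carbon did not give the same step on the two cores: the same change on two cores in this assay, a 2.9-fold higher number (0.46 log units; beyond the scatter) from compound 1 to compound 2 and a 1.3-fold lower number (0.12 log units; within the scatter) from compound 3 to compound 4, 3.9-fold (0.59 log units) apart, beyond the scatter of two such steps. Methyl in place of oxolan-3-yl on the oxygen likewise gave different steps depending on the group carried at the other place: the same change on two cores in this assay, a 6.8-fold higher number (0.83 log units; beyond the scatter) from compound 1 to compound 3 and a 1.8-fold higher number (0.24 log units; within the scatter) from compound 2 to compound 4, 3.9-fold (0.59 log units) apart, beyond the scatter of two such steps. The new steps, a 1.3-fold lower number from compound 3 to compound 4 (0.12 log units; within the scatter) and a 1.8-fold higher number from compound 2 to compound 4 (0.24 log units; within the scatter), both lie within the scatter, so in these four compounds each change gave a step beyond the scatter only on compound 1, while a single set of four compounds in one assay shows neither why this is so nor whether it would recur elsewhere in the series.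

The compounds shown leave open how other groups at that aromatic carbon, such as dimethylamino or a morpholine, would behave on the two cores. They also leave open whether an ethyl group or a longer chain ending in an amine on the oxygen would follow compound 1 or compound 3 in this assay.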